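This account rests on a few compounds, and the source may have more. Where it says the series, first, only, none or still open, it means among the compounds named here.

In an in vivo ADME assay on the whole organism for pharmacokinetics, with Rattus norvegicus as the target, at a dose of 5 mg/kg (a higher number here means faster removal of the compound, a lower number slower removal), compound 2 (`Cc1ccc([C@H](C(=O)N(C)C)N2C(=O)[C@@H](C3Cc4ccccc4C3)NC(=O)[C@H]2CC(C)C)cn1`) gives 18 mL/min/kg and compound 1 (`CCC(CC)[C@@H]1C(=O)N[C@H](C2Cc3ccccc3C2)C(=O)N1[C@@H](C(=O)N1CCOCC1)c1ccc(C)nc1`) gives 23 mL/min/kg. Among the compounds with values here, these two values lie within the scatter of each other, so compound 2 cannot be separated from the only other measured compound. Compound 3 (`CCC(CC)[C@@H]1C(=O)N[C@H](C2Cc3ccccc3C2)C(=O)N1[C@@H](C(=O)N(C)C)c1ccc(C)nc1`) has not yet been measured. It departs from compound 2 in one place, with pentan-3-yl in place of isobutyl on a saturated ring carbon. Within the data shown here, no measured pair isolates this change, because compound 1 also differs from compound 2 elsewhere. Still, compound 1 carries pentan-3-yl as well, and its 23 mL/min/kg gives no sign of a large effect. The expected result is therefore no change beyond the scatter, with an estimated 1.1-fold higher number from compound 2 to compound 3 (0.05 log units; within the scatter). Compound 3 is expected to give 20 mL/min/kg, with an estimated range from 11 mL/min/kg to 36 mL/min/kg.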

Compound 3, clearance: 20 mL/min/kg
Compound 3: the middle estimate sits on the measured number at the digits printed; the measured number falls inside the stated range.
By their numbers in this assay, from the lowest: compounds 2, 3 and 1 (each within the scatter of the next).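

Within the data shown here, compound 3 gives the first step that isolates this position in this assay, and a 1.1-fold higher number from compound 2 to compound 3 (0.05 log units; within the scatter) shows that pentan-3-yl in place of isobutyl on this saturated ring carbon stays within the scatter. It also isolates a second place, on a carbonyl carbon, where dimethylamino in place of morpholin-4-yl gives a 1.2-fold lower number from compound 1 to compound 3 (0.06 log units; within the scatter) and likewise stays within the scatter, so neither single change separates the compounds in clearance.

Among these compounds, only two branched alkyl groups appear on the ring carbon, so the effect of an amine, a carboxylic acid or a cyclohexyl ring there remains open. On these data alone, on the carbonyl carbon only dimethylamino and morpholin-4-yl appear, so the effect of a piperazine there also remains open.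

No measured information accounts for these results.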